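The source may hold more compounds than are shown below. What is called first, only, known or untested is meant among the compounds shown, and "the series" means these compounds.

Measured so far in an ADME assay on CEM-SS cells (Homo sapiens) for cytotoxicity, read by XTT assay; a higher number here means that more compound is tolerated, a lower number that less compound is tolerated:
- Compound 1 `CN1CCN(Cc2cn(Cc3ccc(F)cc3)c3cnc(C(=O)N(C)O)cc23)CC1` gives > 224000 nM, which is a limit of the assay.
- Compound 2 `CCOCCOCc1cn(Cc2ccc(F)cc2)c2cnc(C(=O)N(C)O)cc12` gives 81000 nM.

Among the measured compounds shown here, compound 2 holds the only actual number in this assay, since the other result is a limit. Compound 3 `CN(O)C(=O)c1cc2c(C(=O)N3CCC[C@@H]3CO)cn(Cc3ccc(F)cc3)c2cn1` keeps the shared core and changes one group, on an aromatic carbon of a five-membered aromatic ring: (2-(hydroxymethyl)pyrrolidin-1-yl)carbonyl in place of (2-ethoxyethoxy)methyl on an aromatic carbon. For the measured compounds named here, one measured step bears on this change, as it also swaps the group at this place: an at least 2.7-fold lower number from compound 1 to compound 2 (0.44 log units; beyond the scatter). That step lies beyond the scatter, so a swap here can move the number, but it involves a different pair of groups and gives no firm direction. The expected result is therefore no clear shift, namely a 1.2-fold higher number from compound 2 to compound 3 (0.09 log units; within the scatter), which would stay within the scatter. For compound 3 the estimated value is 100000 nM, with an expected range from 30000 nM to 230000 nM.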

Compound 3, half-maximal cytotoxic concentration: > 32000 nM
Compound 3: only a limit was reported (the forecaster's own chance of this, stated with the estimate: 35%); the middle value does not contradict the limit.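

Compound 3 gives > 32000 nM, which is a limit of the assay and not a number. Its steps from compound 1 and compound 2 therefore cannot be read. The compounds shown leave open whether (2-(hydroxymethyl)pyrrolidin-1-yl)carbonyl in place of (2-ethoxyethoxy)methyl changes the tolerated concentration at all.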